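Replacing a trifluoromethylphenyl with a bromophenyl in a quinazoline series

This account rests on a few compounds, and the source may have more. Where it says the series, first, only, none or still open, it means among the compounds named here.

Compound 3 `FC(F)(F)c1ccc(-c2nc(NCc3ccc(-c4cccnc4)cc3)c3ccccc3n2)cc1` is reported in an assay on a protein complex for inhibition of ubiquitin carboxyl-terminal hydrolase 1/WD repeat-containing protein 48 (Homo sapiens), read by fluorescence (a lower number here means a stronger inhibitor, a higher number a weaker inhibitor), as "not active" (no number reported), with no number given, so it has no standing on the scale on which the others are placed. Among the compounds with values here, its companion compound 1 `FC(F)(F)c1ccccc1-c1nc(NCc2ccc(-c3ccc(Cl)cc3)cc2)c2ccccc2n1` gives 3600 nM in this assay, and compound 2 `FC(F)(F)c1ccccc1-c1nc(NCc2ccc(C3CCCCC3)cc2)c2ccccc2n1` gives 9800 nM; the only measured step, a 2.7-fold higher number from compound 1 to compound 2 (0.43 log units; beyond the scatter), concerns a different site from the one altered here, so it does not bear directly on the change. Compound 4 `Brc1ccccc1-c1nc(NCc2ccc(-c3cccnc3)cc2)c2ccccc2n1` differs from compound 3 by 2-bromophenyl in place of 4-(trifluoromethyl)phenyl on an aromatic carbon. Within the data shown here, no measured step in this assay touches this exchange, and compound 3 offers no number to step from; all that can be said is that the shared core has reached the micromolar range in compound 1 and compound 2. Compound 4 is therefore expected to fall near 6000 nM, within a broad range from 1000 nM to 40000 nM, with a real chance that this assay again reports no number.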

Compound 4, half-maximal inhibitory concentration: 1600 nM
Estimate against measurement, compound 4: 3.8-fold (0.57 log units) above; low and high end bracket the measured number.
By their numbers in this assay, from the lowest: compound 4; then compound 1; then compound 2.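

Compound 3 carries no number in this assay while compound 4 gives 1600 nM, and no step can be read between them. The compounds shown leave open how much the 2-bromophenyl exchange itself contributes, and no evidence here bears on this result.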